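The source may hold more compounds than are shown below. What is called first, only, known or untested is meant among the compounds shown, and "the series" means these compounds.

Compound 3 `CCCCCCCCCCCSC(=S)C1=C(Nc2ccc(Br)cc2)CC(C)(C)CC1=O` stands only at a limit. In a functional assay on PBMC cells (Homo sapiens) for inhibition, read by ELISA, with a stated time of 18 h (a higher number here means a weaker inhibitor, a lower number a stronger inhibitor), compound 3 gives > 20 ug/mL, which is a limit of the assay and not a number. Compound 2 `CCCCSC(=S)C1=C(Nc2ccc(Br)cc2)CC(C)(C)CC1=O` gives > 20 ug/mL in this assay, also a limit. The step that the two limits leave unreadable from compound 2 to compound 3 therefore cannot be read. Compound 1 `CC1(C)CC(=O)C(C(=S)SCc2ccccc2)=C(Nc2ccc(Cl)cc2Cl)C1` gives > 20 ug/mL in this assay, again a limit, and in fact (the limit of > 20 ug/mL in this assay, at which 3 of the 3 values shown sit). Compound 4 `CC1(C)CC(=O)C(C(=S)SCc2ccccc2)=C(Nc2ccc(Br)cc2)C1` differs from compound 3 by phenyl in place of decyl on a saturated chain carbon bound to a sulfur. Among the measured compounds shown here, no measured step has a readable size for this change. Because compound 1 carries the same phenyl on the carbon bound to sulfur and gives > 20 ug/mL in this assay, no step beyond the scatter is expected. Compound 4 is therefore expected to give 30 ug/mL (range 15 ug/mL to 100 ug/mL), an expected step that the limit leaves unreadable from compound 3 to compound 4.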

Compound 4, half-maximal inhibitory concentration: > 20 ug/mL
Compound 4: no number, only a limit; the forecaster's own chance of this, stated with the estimate: 85%; the middle value lies beyond the limit too.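

No new step can be read from compound 1, compound 2, compound 3 and compound 4, since in this assay all four stand only at a limit: the limit of > 20 ug/mL in this assay, at which 4 of the 4 values shown sit.

The compounds shown leave open how strongly each one inhibits, and whether the changes among them alter that at all.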